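Thioether aryl swap on the benzamide series

The compounds below may be only part of what the source reports. "The series", "measured", "known", "first", "only" and "open" are said of these compounds alone.

Notes on a small set sharing one core. Compound 1 `COc1ccc(SCc2ccc(C(=O)Nc3ccccc3N)cc2)cc1` carries a 4-methoxyphenyl on the sulfur and, in a functional assay on A549 cells (Homo sapiens) for inhibition, read by CCK-8 assay, with a stated time of 72 h, tested at 2 uM (on this read-out lower numbers stand for less inhibition of growth and higher numbers for more inhibition of growth at the one concentration tested), compound 1 gives 45.7%. Among the compounds with values here, compound 2 `Cc1cc(C)cc(SCc2ccc(C(=O)Nc3ccccc3N)cc2)c1` carries a 3,5-dimethylphenyl at the same sulfur, and in this assay compound 2 gives 33.3%; the single step recorded, a number 12.4 percentage points lower from compound 1 to compound 2 (beyond the scatter), leaves compound 2 as the lower of the two numbers so far. Compound 3 `CCc1ccc(SCc2ccc(C(=O)Nc3ccccc3N)cc2)cc1` is the next member: 4-ethylphenyl in place of 3,5-dimethylphenyl on a sulfur. Within the data shown here, no measured step covers this exact exchange; the only one known concerns a different pair of aryl groups on the same sulfur and was modest in size. The expectation for this assay is therefore a step of about a number 4.7 percentage points higher from compound 2 to compound 3 (within the scatter), not clearly beyond the scatter in either direction. For compound 3 the estimate in this assay is 38%, with a range from 25% to 52%.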

Compound 3, percent growth inhibition at one concentration: 53.6%
Compound 3: the middle estimate sits 15.6 percentage points below what was measured; the whole stated range lies below it.
By their numbers in this assay, from the lowest: compound 2; then compounds 1 and 3 (each within the scatter of the next).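

In this assay, the rearrangement of the same carbon atoms on the aryl group on the sulfur is enough to shift the read-out, with a number 20.3 percentage points higher from compound 2 to compound 3 (beyond the scatter); at this position, the arrangement of the substituent carbons matters and not only the atoms present. Ethyl and methoxy on an aromatic carbon cannot be separated here, with a number 7.9 percentage points higher from compound 1 to compound 3 (within the scatter), so among these three compounds only the 3,5-dimethylphenyl of compound 2 stands apart, its steps to both others lying beyond the scatter. No measured property bears on why the 4-ethylphenyl and 3,5-dimethylphenyl groups differ in this way.

Open, going by these compounds, is whether a propyl chain in place of the ethyl would hold the number of compound 3 or lose it. An amine or a carboxylic acid in place of the ethyl is equally open, as is any read-out beyond the single concentration and cell line shown.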